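The source may hold more compounds than are shown below. What is called first, only, known or untested is meant among the compounds shown, and "the series" means these compounds.

Compound 1 `COC(=O)c1scc(-c2ccc(NC(=O)c3ccc(F)c(Cl)n3)cc2)c1OC` carries a 6-chloro-5-fluoropyridin-2-yl group on a carbonyl carbon, and in an ADME assay on HEK293 cells (Homo sapiens) for cytotoxicity, read by MTT assay, with a stated time of 24 h (on this read-out lower numbers stand for stronger inhibition and higher numbers for weaker inhibition), compound 1 has the entry "not determined" (no result reported) and so offers no number to start from. Compound 3 `COC(=O)c1scc(-c2ccc(NC(=O)c3ccc(C#N)nc3)cc2)c1OC` is no help either, since compound 3 also shows "not determined" (no result reported) as its entry. For the measured compounds named here, the only number in this small set comes from compound 2 `COC(=O)c1scc(-c2ccc(NC(=O)c3cc(I)ccc3F)cc2)c1OC`, which reads 45300 nM in this assay and shares the core of compound 1.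

Compound 4 `COC(=O)c1scc(-c2ccc(NC(=O)c3ccc(C(F)(F)F)cc3)cc2)c1OC` differs from compound 1 in one place: 4-(trifluoromethyl)phenyl in place of 6-chloro-5-fluoropyridin-2-yl on a carbonyl carbon with 4-(trifluoromethyl)phenyl in place of 6-chloro-5-fluoropyridin-2-yl on a carbonyl carbon. Going by the values given here, no measured pair shows what such a swap does, and the step from compound 1 cannot be sized without a starting value. Among the compounds with values here, the best guide is therefore compound 2 at 45300 nM as the one reading for this core. Compound 4 is expected to land near that reading in this assay, with no shift in either direction beyond the usual scatter of repeated measurements. For compound 4 the estimated value is 45000 nM, with an expected range from 15000 nM to 130000 nM as the likely span.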

Compound 4, half-maximal inhibitory concentration: 48300 nM
Estimate against measurement, compound 4: 1.1-fold (0.03 log units) below, within the range that was stated.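

In this assay, putting 4-(trifluoromethyl)phenyl in place of 2-fluoro-5-iodophenyl on a carbonyl carbon gives a 1.1-fold higher number from compound 2 to compound 4 (0.03 log units; within the scatter), so the two readings cannot be told apart. For the compounds shown here, this is the first pair in the set with a number on both sides, and it shows that on this shared core, at the place where the carbonyl carbon also bonds to an amide-type nitrogen, these two quite different substituted phenyl groups give the same result within normal assay scatter, even though one carries iodine and fluorine and the other a trifluoromethyl group. Nothing available here offers an explanation for this match.

Two groups are a small sample, so this pair cannot say whether the position tolerates change in general, and a phenyl group bearing an amine or a carboxylic acid could behave differently on the same core. Going by these compounds alone, the pyridine-containing groups also remain open, as no step involving compound 1 or compound 3 can be read, which leaves any comparison between those rings and the phenyl groups of compound 2 and compound 4 out of reach.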